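This account rests on a few compounds, and the source may have more. Where it says the series, first, only, none or still open, it means among the compounds named here.

Three compounds share one core. Compound 1 `Cc1ccc2ccc(-c3cccc(Cl)c3)cc2n1` gives 14000 nM in a functional assay on CHO cells for inhibition of metabotropic glutamate receptor 5 (Rattus norvegicus), read by FLIPR and calcium flux; on this read-out higher numbers stand for weaker inhibition and lower numbers for stronger inhibition. Compound 2 `Cc1ccc2ccc(-c3ccc(C#N)cc3)cc2n1` returns only > 10000 nM in this assay, which is a limit of the assay and not a number. Compound 3 `Cc1ccc2ccc(-c3cc(C#N)cc(C#N)c3)cc2n1` gives 2 nM in this assay, the lowest of the two numbers in hand and far below compound 1. Compound 4 `Cc1ccc2ccc(-c3cc(C#N)cc(OCC(C)C)c3)cc2n1` differs from compound 3 in one place: isobutoxy in place of cyano on an aromatic carbon. Among the compounds with values here, no measured pair shows what such a change does, so the expectation rests on compound 3 alone. A moderate weakening is expected in this assay, estimated as a 15-fold higher number from compound 3 to compound 4 (1.18 log units; beyond the scatter). Compound 4 is therefore expected to give about 30 nM, within a range from 5 nM to 200 nM.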

Compound 4, half-maximal inhibitory concentration: 12000 nM
Estimate against measurement, compound 4: 400-fold (2.60 log units) below; the whole stated range lies below it.
By their numbers in this assay, from the lowest: compound 3; then compounds 4 and 1 (each within the scatter of the next).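

Swapping one cyano group for isobutoxy at this position is enough to lose nearly all the inhibition seen in this assay, with a 6000-fold higher number from compound 3 to compound 4 (3.78 log units; beyond the scatter). The other cyano group stays in place in compound 4, so that group alone does not keep the number low. Compound 2 gives only a limit and not a number: the limit of > 10000 nM in this assay, at which 1 of the 4 values shown sits.

Going by these compounds, whether a methoxy group, an amine or a carboxylic acid at this position would keep the number low stays open. So does whether the oxygen or the branched chain of isobutoxy matters more.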